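The compounds below may be only part of what the source reports. "The series", "measured", "known", "first", "only" and "open" are said of these compounds alone.

Measured so far in an assay on HEK293 cells for inhibition of Voltage-dependent T-type calcium channel subunit alpha-1G (Homo sapiens), read by fluorescence, tested at 10 uM; on this read-out higher numbers stand for more inhibition at the one concentration tested (going by the name of the read-out) and lower numbers for less inhibition:

- compound 1, `CCCc1nc(-c2ccccc2)c(CNCCCN2CCN(c3ccc(OC)cc3)CC2)o1`: 42.1%
- compound 2, `CCCc1nc(-c2ccccc2)c(CNCCCN2CCN(c3ccc(C(F)(F)F)cc3)CC2)o1`: 51.6%

Among the compounds with values here, compound 2 carries the higher of the two numbers, but the single step of a number 9.5 percentage points higher from compound 1 to compound 2 (within the scatter) lies within the scatter, so the two compounds cannot be separated on this assay.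

The next compound, compound 3 `CCCc1nc(-c2ccccc2)c(CNCCCN2CCN(c3ccc(C)cc3)CC2)o1`, is not yet measured. Its change from compound 2 is methyl in place of trifluoromethyl on an aromatic carbon; cut one bond further out it reads 4-(trifluoromethyl)phenyl to 4-methylphenyl. Within the data shown here, the only step that bears on this position is a number 9.5 percentage points higher from compound 1 to compound 2 (within the scatter), which stayed within the scatter, so no basis exists for expecting a step beyond the scatter here either.

For compound 3 the estimate in this assay is 45%, expected to fall between 25% and 65%. The expected step of a number 6.6 percentage points lower from compound 2 to compound 3 (within the scatter) is thus estimated to stay within the usual scatter.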

Compound 3, a percentage reported as inhibition, at one concentration (the size of the read-out at that concentration, not a potency): 53.9%
Compound 3: the middle estimate sits 8.9 percentage points below what was measured, and the stated range covers the measured number.
By their numbers in this assay, from the lowest: compounds 1, 2 and 3 (each within the scatter of the next, the first and the last beyond it).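

In this assay the exchange of trifluoromethyl for methyl, on an aromatic carbon para to a large group, gives a number 2.3 percentage points higher from compound 2 to compound 3 (within the scatter) and so does not separate these two compounds. The same position now also yields its first step beyond the scatter, as methyl in place of methoxy gives a number 11.8 percentage points higher from compound 1 to compound 3 (beyond the scatter) and this modest step stands where the earlier trifluoromethyl and methoxy pair could not be separated. No evidence is available to account for either step.

The compounds shown leave open how an amine, a carboxylic acid or a longer chain would read at this position. With one concentration per compound, they also leave open whether the modest step between methoxy and methyl would hold as a difference in potency.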